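This account rests on a few compounds, and the source may have more. Where it says the series, first, only, none or still open, it means among the compounds named here.

Measured compounds:
compound 1 `CCCNc1nc(C)nc2c1cnn2-c1ccccc1` — > 100000 nM
compound 2 `CCN(CC)c1nc(C)nc2c1cnn2-c1ccccc1` — > 100000 nM

In a functional assay on G-361 cells (Homo sapiens) for cytotoxicity, read by sulforhodamine B assay (a lower number here means that less compound is tolerated, a higher number that more compound is tolerated), compound 1 gives only a limit, > 100000 nM. Compound 2 also reaches only a limit in this assay, > 100000 nM. The step that the two limits leave unreadable from compound 1 to compound 2 therefore has no readable size, because both values sit at the limit of > 100000 nM in this assay, at which 2 of the 2 values shown sit. Compound 1 thus stands at the edge of what this assay can report, with no measured number to place it more exactly.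

Compound 3 `CCNc1nc(C)nc2c1cnn2-c1ccccc1` differs from compound 1 by hydrogen in place of methyl on a saturated chain carbon, two bonds along the chain from a nitrogen on an aromatic ring. Within the data shown here, no measured step covers this kind of change; the one measured step, from propylamino to diethylamino, is itself unreadable. The step that the limit leaves unreadable from compound 1 to compound 3 is therefore expected to stay within the scatter, with compound 3 most likely again at the limit of this assay. Compound 3 is expected to give 150000 nM, in a range from 50000 nM to 500000 nM.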

Compound 3, concentration lethal to 50% of the cells: > 100000 nM
Compound 3 gave a limit, no number (the forecaster's own chance of this, stated with the estimate: 85%); the middle value is on the limit's open side.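

No new step can be read among compound 1, compound 2 and compound 3 in this assay, because all three values are limits: the limit of > 100000 nM in this assay, at which 3 of the 3 values shown sit.

The compounds shown leave open whether propylamino, diethylamino and ethylamino on the shared core differ at all in this assay, and by how much.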